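Phenethyl amide in a series held at a cytotoxicity limit

The source may report more compounds than this note shows. Statements on the series, on what has been measured and on what is new or still open speak of the compounds shown alone.

Measured compounds:
Compound 1, `CCCCCC(=O)Nc1cc2nc(C3CCCCC3)[nH]c2cc1N1CCCC1`, gives > 100 ug/mL in an ADME assay on Vero cells (Chlorocebus sabaeus) for cytotoxicity, read by resazurin assay, with a stated time of 3 days (a higher number here means a weaker inhibitor, a lower number a stronger inhibitor), which is a limit of the assay and not a number.
Compound 2, `O=C(Nc1cc2nc(C3CCCCC3)[nH]c2cc1N1CCCC1)c1ccc(Br)cc1`, gives > 100 ug/mL in this assay, again a limit rather than a number.

Among the compounds with values here, compound 2 therefore stands at the top of what this assay can report, a position it shares with the only other measured compound, as the limit of > 100 ug/mL in this assay, at which 2 of the 2 values shown sit, shows. Within the data shown here, the one measured step, a step that the two limits leave unreadable from compound 1 to compound 2, cannot be read in size or direction, since both of its ends are limits.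

The next compound, compound 3, `O=C(CCc1ccccc1)Nc1cc2nc(C3CCCCC3)[nH]c2cc1N1CCCC1`, differs from compound 2 by phenethyl in place of 4-bromophenyl on a carbonyl carbon. Among the measured compounds shown here, no measured step bears on this change in a readable way: the only step available is the unreadable one from the pentyl amide to the 4-bromophenyl amide. With both measured values sitting at the limit, the expected step that the limit leaves unreadable from compound 2 to compound 3 is none beyond the scatter. Compound 3 is therefore estimated at 130 ug/mL, with a range from 60 ug/mL to 300 ug/mL, and most likely this assay will again report only a limit for it.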

Compound 3, half-maximal inhibitory concentration: > 100 ug/mL
Compound 3: only a limit was reported; the forecaster's own chance of this, stated with the estimate: 80%; the middle value lies beyond the limit too.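

Compound 3 gives > 100 ug/mL in this assay, which is again a limit of the assay and not a number. No step among compound 1, compound 2 and compound 3 can therefore be read, in size or in direction: the limit of > 100 ug/mL in this assay, at which 3 of the 3 values shown sit.

The compounds shown leave open whether the pentyl, 4-bromophenyl and phenethyl groups differ at all in this assay.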